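From acetyl to (ethoxycarbonyl)carbonyl on the core of compound 1

A few compounds are considered here, and "the series" means these few. Any claim that something is new, unique, unknown or untested is made for them only; others in the source may bear on it.

Compound 1 `COc1cc(C2OC(c3ccc(N(C)C)cc3)=NN2C(C)=O)cc(OC)c1OC` gives 0.033 uM
Compound 2 `COc1cc(C2OC(c3cccc(N(C)C)c3)=NN2C(C)=O)cc(OC)c1OC` gives 0.16 uM

In a functional assay on HCT-15 cells (Homo sapiens) (on this read-out lower numbers stand for an effect already at smaller amounts and higher numbers for an effect only at larger amounts of compound), compound 1 holds the lower of the two numbers (0.033 uM), so it acts at the smaller amount. Compound 3 (`CCOC(=O)C(=O)N1N=C(c2ccc(N(C)C)cc2)OC1c1cc(OC)c(OC)c(OC)c1`) keeps the core of compound 1 but has ethoxycarbonyl in place of methyl on a carbonyl carbon. Cut one bond further out, this reads acetyl to (ethoxycarbonyl)carbonyl. For the measured compounds named here, only one measured step exists (a 4.8-fold higher number from compound 1 to compound 2 (0.69 log units; beyond the scatter)), and it swaps 4-(dimethylamino)phenyl for 3-(dimethylamino)phenyl, so it leaves this carbonyl carbon untouched. It bears on the new change only indirectly, as a guide to size, and the size of this new step remains uncertain. A modest upward step of similar size is therefore expected (a 3.6-fold higher number from compound 1 to compound 3 (0.56 log units; beyond the scatter)). The estimate for compound 3 is 0.12 uM, within an expected range of 0.025 uM to 0.6 uM.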

Compound 3, concentration for half-maximal effect: 45 uM
Estimate against measurement, compound 3: 380-fold (2.57 log units) below; the measured number lies above the stated range.
By their numbers in this assay, from the lowest: compound 1; then compound 2; then compound 3.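

The carbonyl carbon that the earlier step left untouched turns out to be a very sensitive place: in this assay, ethoxycarbonyl in place of methyl gives a 1400-fold higher number from compound 1 to compound 3 (3.13 log units; beyond the scatter), whereas 3-(dimethylamino)phenyl in place of 4-(dimethylamino)phenyl gave only a 4.8-fold higher number from compound 1 to compound 2 (0.69 log units; beyond the scatter). On the shared core, the group on this carbon therefore has the larger effect of the two changes shown. Nothing available explains this loss of effect at larger scale or says what drives it.

This single change replaces methyl, with 1 heavy atom, by ethoxycarbonyl, with 5 heavy atoms and 2 hydrogen-bond acceptors, so these differences cannot be told apart here. Open, too, is how a plain ethyl chain, which adds length without the ester, or a carboxylic acid in place of the ethyl ester would behave at this carbon.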